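From a Hydroxyheptyl Tail to a Carboxylic Acid

The source may report more compounds than this note shows. Statements on the series, on what has been measured and on what is new or still open speak of the compounds shown alone.

Three compounds have been measured in an assay on cells for binding affinity to vitamin D3 receptor (Homo sapiens), read by fluorescence, tested at 1 uM; on this read-out lower numbers stand for less inhibition and higher numbers for more inhibition at the one concentration tested (going by the name of the read-out):
compound 1 `CCC(CC)(c1ccc(OS(=O)(=O)c2ccc(C)cc2)c(C)c1)c1ccc(OCC(O)C(C)(C)C)c(OCC(O)C(C)(C)C)c1` gives 43%;
compound 2 `CCC(CC)(c1ccc(OCCO)c(C)c1)c1ccc(OCC(O)C(C)(C)C)c(OCC(O)C(C)(C)C)c1` gives 38%;
compound 3 `CCC(CC)(c1ccc(OCCCCCCCO)c(C)c1)c1ccc(OCC(O)C(C)(C)C)c(OCC(O)C(C)(C)C)c1` gives 5%.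

Compound 3 stands lowest of the three, by a number 38 percentage points lower from compound 1 to compound 3 (beyond the scatter) and by a number 33 percentage points lower from compound 2 to compound 3 (beyond the scatter), both beyond the scatter. Compound 4 `CCC(CC)(c1ccc(OCCCCC(=O)O)c(C)c1)c1ccc(OCC(O)C(C)(C)C)c(OCC(O)C(C)(C)C)c1` differs from compound 3 in one place: carboxy in place of 3-hydroxypropyl on a saturated chain carbon, four bonds along the chain from an oxygen on an aromatic ring. Among the compounds with values here, no measured step replaces a hydroxy-terminated chain with a carboxy group, so the measured steps bear only indirectly. The large downward step a number 33 percentage points lower from compound 2 to compound 3 (beyond the scatter) came with lengthening the hydroxyalkyl chain; compound 4 instead carries a shorter chain ending in carboxy, a change of uncertain size. The expected value for compound 4 is 15%, with a range from 0% to 40%, an expected step of a number 10 percentage points higher from compound 3 to compound 4 (within the scatter).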

Compound 4, a percentage reported as inhibition, at one concentration (the size of the read-out at that concentration, not a potency): "not active" (no number reported)
The entry for compound 4 holds no number, so the estimate cannot be set against anything.
By their numbers in this assay, from the lowest: compound 3; then compounds 2 and 1 (each within the scatter of the next).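

Within the data shown here, compound 4 is recorded as "not active" with no number, so no step linking it to compound 3 can be read. No supporting measurement bears on this result. The compounds shown leave open how compound 4 and compound 3 compare numerically.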